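Benzyl replaces methyl on the saturated ring of compound 2

The compounds below may be only part of what the source reports. "The series", "measured", "known", "first", "only" and "open" are said of these compounds alone.

Compound 1 `CC(C(=O)NCc1ccc(C(F)(F)Cl)nc1N1CCCCCC1)c1ccc(NS(C)(=O)=O)c(F)c1` gives 0.5 nM in an assay on CHO cells for antagonist activity at transient receptor potential cation channel subfamily V member 1 (Homo sapiens), read by FLIPR; on this read-out higher numbers stand for weaker inhibition and lower numbers for stronger inhibition. Within the data shown here, compound 2 `Cc1cc(C(F)(F)F)nc(N2CCC(C)CC2)c1CNC(=O)C(C)c1ccc(NS(C)(=O)=O)c(F)c1` gives 17.5 nM in this assay, the higher of the two numbers, and the two compounds differ in more than one place, so no single step connects them. Compound 3 `Cc1cc(C(F)(F)F)nc(N2CCC(Cc3ccccc3)CC2)c1CNC(=O)C(C)c1ccc(NS(C)(=O)=O)c(F)c1` carries phenyl in place of hydrogen on a saturated chain carbon bound to a saturated ring carbon. No step between measured compounds is shown, so the effect of this change is unknown. The step of a 1.1-fold higher number from compound 2 to compound 3 (0.06 log units; within the scatter) is expected to stay within the usual scatter. Compound 3 is therefore estimated at 20 nM in this assay, with a range from 5 nM to 80 nM.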

Compound 3, inhibition constant: 9.2 nM
For compound 3 the middle estimate is 2.2-fold (0.34 log units) above the measured one; the measured number falls inside the stated range.
By their numbers in this assay, from the lowest: compound 1; then compounds 3 and 2 (each within the scatter of the next).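

Going from methyl to benzyl on a saturated chain carbon bound to a saturated ring carbon gives a 1.9-fold lower number from compound 2 to compound 3 (0.28 log units; within the scatter) and so leaves the two compounds indistinguishable in this assay. Among these compounds, this position therefore takes an added phenyl, a six-membered aromatic ring of carbon only, with no step beyond the scatter, which the earlier compounds could not show. Nothing available explains this result. The compounds shown leave open whether a longer chain ending in phenyl would also stay within the scatter of compound 2. The same question stands for an amine or a carboxylic acid at this carbon.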